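This account rests on a few compounds, and the source may have more. Where it says the series, first, only, none or still open, it means among the compounds named here.

Measured in a physicochemical assay for solubility, using the shake flask method, in phosphate buffer, with a stated time of 24 h, at pH 7.4; on this read-out lower numbers stand for lower solubility and higher numbers for higher solubility:

compound 1 `O=c1c2cn(C3COC3)nc2nc(SCc2cccc(F)c2)n1-c1ccccc1` gives 5000 nM
compound 2 `Cn1ncc2c(=O)n(-c3ccccc3)c(/C=C/c3cccc(F)c3)nc21` gives 4000 nM
compound 3 `CC(Sc1nc2c(cnn2C)c(=O)n1-c1ccccc1)c1ccccc1` gives 8000 nM

All three numbers lie within the usual scatter of one another, so compound 3 cannot be set apart from compound 1 or compound 2 on these values; the three compounds share a core and differ in the group carried on it. Compound 4 `CC(Sc1nc2c(cnn2C)c(=O)n1-c1ccccc1)c1cccnc1` has not yet been measured in this assay. It differs from compound 3 in one place: pyridin-3-yl in place of phenyl on a saturated chain carbon bound to a saturated chain carbon and a sulfur. For the measured compounds named here, no measured pair shows this same change, so there is no step to lean on. The counted difference is one hydrogen-bond acceptor entering with the pyridin-3-yl ring, and on that alone a modest rise in this assay is expected, somewhat beyond the scatter but not large, because compound 3 already gives 8000 nM. The expected step is a 2.5-fold higher number from compound 3 to compound 4 (0.40 log units; beyond the scatter). Compound 4 is therefore estimated at 20000 nM, within a range from 8000 nM to 50000 nM.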

Compound 4, solubility: 209000 nM
Estimate against measurement, compound 4: 10-fold (1.02 log units) below; measured number outside the range, above it.
By their numbers in this assay, from the lowest: compounds 2, 1 and 3 (each within the scatter of the next); then compound 4.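

In this assay, pyridin-3-yl in place of phenyl on a saturated chain carbon bound to a saturated chain carbon and a sulfur gives a 26-fold higher number from compound 3 to compound 4 (1.42 log units; beyond the scatter). For the compounds shown here, this is the first step that can be read, as the earlier compounds differ from one another in more than one place and offered no such comparison. It shows that this position is sensitive to the ring it carries: the two rings have the same number of heavy atoms, yet a single ring nitrogen, counted as one hydrogen-bond acceptor, accompanies a large step.

Nothing given here explains why the step is so large. Going by these compounds, it also remains open how this position would respond to a pyrimidine ring, or to an amine or a carboxylic acid carried on the ring.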